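This account rests on a few compounds, and the source may have more. Where it says the series, first, only, none or still open, it means among the compounds named here.

Working notes on the series. Compound 1 `CNC(=O)c1cc(Oc2ccc(/C=C/C(=O)c3ccc([N+](=O)[O-])cc3)cc2)ccn1` carries no result in a functional assay on PC-3 cells (Homo sapiens) for cytotoxicity, read by MTT assay, with a stated time of 72 h; on this read-out lower numbers stand for stronger inhibition and higher numbers for weaker inhibition: for compound 1 the entry reads "not determined" (no result reported). Compound 3 `CNC(=O)c1cc(Oc2ccc(/C=C/C(=O)c3ccc(Cl)cc3)cc2)ccn1` is in the same position: in this assay compound 3 gives "not determined" (no result reported). Compound 2 `CNC(=O)c1cc(Oc2ccc(C(=O)/C=C/c3ccc(C#N)cc3)cc2)ccn1` therefore stands alone with the only number shown: in this assay compound 2 gives 3870 nM. Among the measured compounds shown here, no step between two measured compounds can be drawn from these entries.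

Compound 4 `CNC(=O)c1cc(Oc2ccc(C(=O)/C=C/c3ccc(F)cc3)cc2)ccn1` has not yet been measured in this assay. It differs from compound 2 in one place: fluoro in place of cyano on an aromatic carbon. For the measured compounds named here, with no measured step available to guide the size, the expectation is a shift from compound 2 to compound 4 of about a 1.3-fold higher number from compound 2 to compound 4 (0.11 log units; within the scatter), toward the weaker side but within the usual scatter. Compound 4 is thus estimated at 5000 nM, with a plausible range from 2000 nM to 15000 nM.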

Compound 4, half-maximal inhibitory concentration: 6140 nM
Compound 4: the middle estimate sits 1.2-fold (0.09 log units) below what was measured, and the stated range covers the measured number.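

In this assay, among the compounds shown here, fluoro in place of cyano on this aromatic carbon gives a 1.6-fold higher number from compound 2 to compound 4 (0.20 log units; within the scatter), the first readable step. At this position, the two groups therefore cannot be told apart, although the change removes a triple bond and a hydrogen-bond acceptor. No measured evidence bearing on this result is available.

Left open is how an amine, a carboxylic acid or a longer chain on this aromatic carbon would read in this assay. Also open, as far as these compounds go, is whether any group here gives a step beyond the scatter.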